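From thiophen-3-yl to 1,2-thiazol-5-yl on the shared core

A few compounds are considered here, and "the series" means these few. Any claim that something is new, unique, unknown or untested is made for them only; others in the source may bear on it.

Within the data shown here, compound 2 `c1ccc(-c2ccsc2)c(OCC2=NCCN2)c1` is the one compound here with a number: in a functional assay for activation of Alpha-1B adrenergic receptor (Homo sapiens), read by calcium flux (a lower number here means that less compound is needed, a higher number that more compound is needed for the effect), compound 2 gives 15.9 nM. Compound 1 `c1ccc(-c2ccncn2)c(OCC2=NCCN2)c1` reaches only a limit of this assay, < 100000 nM. The step that the limit leaves unreadable from compound 1 to compound 2 therefore cannot be sized, because the limit of < 100000 nM in this assay, at which 1 of the 2 values shown sits, leaves it unreadable. Compound 3 `c1ccc(-c2ccns2)c(OCC2=NCCN2)c1` carries the change (1,2-thiazol-5-yl in place of thiophen-3-yl on an aromatic carbon). Among the measured compounds shown here, no measured step bears on this change in a readable way, so its direction stays open; a modest weakening is expected, a 3.1-fold higher number from compound 2 to compound 3 (0.50 log units; beyond the scatter). Compound 3 is estimated at 50 nM, with a range from 10 nM to 400 nM.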

Compound 3, half-maximal effective concentration: 12.6 nM
The estimate for compound 3 lay 4.0-fold (0.60 log units) above the measured number, within the range that was stated.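

In this assay, 1,2-thiazol-5-yl in place of thiophen-3-yl gives a 1.3-fold lower number from compound 2 to compound 3 (0.10 log units; within the scatter), so the two groups cannot be told apart here. Among these compounds, on this aromatic carbon, then, a five-membered aromatic ring with 2 hetero atoms serves as well as one with 1 hetero atom, which the earlier compounds could not show. The step from compound 1 to compound 3 cannot be read because compound 1 gives only a limit, not a number: the limit of < 100000 nM in this assay, at which 1 of the 3 values shown sits.

Still open, going by these compounds, is how a plain phenyl ring at this position would read, or a thiophene ring carrying an amine or a carboxylic acid.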